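Fluorine moved on the pyridine of compound 1

This account rests on a few compounds, and the source may have more. Where it says the series, first, only, none or still open, it means among the compounds named here.

Measured in an ADME assay on liver for metabolic stability, with Liver microsome (Rattus norvegicus) as the target, read by LC-MS, using microsomes, with a stated time of 5 h; on this read-out lower numbers stand for slow clearance and higher numbers for fast clearance:
- compound 1 `OC(c1ncccc1F)C1(c2ccc(Cl)c(Cl)c2)CCC1` gives 3000 mL/min/kg
- compound 2 `O[C@H](c1ccccn1)[C@]1(c2cccc(OC(F)(F)F)c2)C[C@@H](O)C1` gives 217 mL/min/kg

Compound 1 stands highest of the two, with compound 2 lower by a margin beyond the scatter. Compound 3 `OC(c1cc(F)ccn1)C1(c2ccc(Cl)c(Cl)c2)CCC1` differs from compound 1 by 4-fluoropyridin-2-yl in place of 3-fluoropyridin-2-yl on a saturated chain carbon bound to an oxygen on a saturated carbon and a saturated ring carbon on the same saturated chain carbon. For the measured compounds named here, no measured step covers this change, so the only close reference is compound 1 at 3000 mL/min/kg in this assay, and no step beyond the scatter is expected. The expected step is a 1.3-fold lower number from compound 1 to compound 3 (0.12 log units; within the scatter) and remains an estimate. Compound 3 is estimated at 2300 mL/min/kg with an expected range of 900 mL/min/kg to 4500 mL/min/kg in this estimate.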

Compound 3, clearance: 3850 mL/min/kg
For compound 3 the middle estimate is 1.7-fold (0.22 log units) below the measured one; the range from low to high includes it.
By their numbers in this assay, from the lowest: compound 2; then compounds 1 and 3 (each within the scatter of the next).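

With 4-fluoropyridin-2-yl in place of 3-fluoropyridin-2-yl, this assay shows a 1.3-fold higher number from compound 1 to compound 3 (0.11 log units; within the scatter) as the first step read at a single place in this series. At this place on the shared core, this exchange of fluoropyridine isomers therefore leaves clearance within the scatter. Nothing measured here offers an explanation for this result.

Still open, going by these compounds, is whether an amine or a carboxylic acid in place of the fluorine on the pyridine would move clearance beyond the scatter. Compound 2 differs from compound 1 in more than one place, so no single change can be credited with its lower number.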